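The source may report more compounds than this note shows. Statements on the series, on what has been measured and on what is new or still open speak of the compounds shown alone.

Measured compounds:
compound 1, `C/C(=N/NC(=S)Nc1ccccc1)c1ccccn1`: 0.18 nM
compound 2, `CC(=NNC(=S)Nc1ccccc1)c1ccccn1`: 0.18 nM
compound 3, `C/C(=N/NC(=S)Nc1ccccc1I)c1ccccn1`: 4.1 nM

Of the compounds shown here, three have been tested in a functional assay on MCF7 cells (Homo sapiens) for cytotoxicity, read by MTT assay, with a stated time of 48 h; on this read-out lower numbers stand for stronger inhibition and higher numbers for weaker inhibition. Compound 1 and compound 2 share the same atoms and bonds; how they are drawn differs in that (the two compounds have the same atoms and bonds; at least one stereo element is drawn with a configuration in one of them and without one in the other: 1 of 1 stereo elements differ; a double bond is drawn Z in compound 1 and without a configuration in compound 2). The step of no change at the digits printed from compound 1 to compound 2 (within the scatter) is consistent with the fact that one of compounds 1 and 2 is drawn with a defined configuration and the other without, at the place where they differ.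

Compound 3 carries iodo in place of hydrogen on an aromatic carbon, and the step of a 23-fold higher number from compound 1 to compound 3 (1.36 log units; beyond the scatter) is a large loss. The change is iodo in place of hydrogen on an aromatic carbon.

Compound 4, `CC(=NNC(=S)Nc1ccc(I)cc1)c1ccccn1`, has not yet been measured in this assay. It differs from compound 2 by iodo in place of hydrogen on an aromatic carbon. Within the data shown here, this is the same kind of change as the one from compound 1 to compound 3, but not the same: in compound 3 the iodo sits ortho to a large group, in compound 4 it sits para to a large group. The only measured step of this kind is the large one from compound 1 to compound 3, a 23-fold higher number from compound 1 to compound 3 (1.36 log units; beyond the scatter); whether a para placement behaves the same way is not shown by any measured pair here.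

Among the measured compounds shown here, the step from compound 2 to compound 4 is expected to be a loss, a 5.6-fold higher number from compound 2 to compound 4 (0.74 log units; beyond the scatter), somewhat smaller than the one seen for compound 3, because the only measured step of this kind is a 23-fold higher number from compound 1 to compound 3 (1.36 log units; beyond the scatter) at a place ortho to a large group rather than para to it. The value of compound 4 in this assay is therefore estimated at 1 nM, probably between 0.2 nM and 6 nM.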

Compound 4, half-maximal inhibitory concentration: 6.6 nM
Beside the measured number, compound 4's estimate is 6.6-fold (0.82 log units) below it, and the stated range ends below it.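

In this assay, iodo in place of hydrogen on an aromatic carbon, para to a large group, gives a 37-fold higher number from compound 2 to compound 4 (1.56 log units; beyond the scatter), a large loss that matches the earlier step in size: the same change on two cores in this assay, a 23-fold higher number (1.36 log units; beyond the scatter) from compound 1 to compound 3 and a 37-fold higher number (1.56 log units; beyond the scatter) from compound 2 to compound 4, 1.6-fold (0.21 log units) apart, within the scatter of two such steps

Within these two pairs, then, the loss carries over from one compound to the other, even though the iodo does not stand at the same place on the ring in compound 3 and compound 4. Among these compounds, what this does not show is that the change would carry over to a core with different atoms: compound 1 and compound 2 have the same atoms and bonds and differ only in how one double bond is drawn, and only two pairs stand behind the comparison.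

The compounds shown leave open whether fluoro, chloro, methoxy or an amine at these places on the ring would give a step like that of iodo. They also leave open whether the iodo step would keep its size on a core in which the methyl on the carbon of the carbon-nitrogen double bond gives way to a longer chain.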